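A few compounds are considered here, and "the series" means these few. Any claim that something is new, unique, unknown or untested is made for them only; others in the source may bear on it.

Values measured in a functional assay on MGC-803 cells (Homo sapiens) for inhibition, read by sulforhodamine B assay; on this read-out lower numbers stand for stronger inhibition and higher numbers for weaker inhibition:

- compound 1 `O=C1C(Nc2ccc(Br)cc2)=CC(=O)c2c1nc1n2[C@H]2OC[C@@H](O)[C@H]2OC1`: 2020 nM
- compound 2 `Cc1ccc(NC2=CC(=O)c3c(nc4n3[C@H]3OC[C@@H](O)[C@H]3OC4)C2=O)cc1`: 1550 nM
- compound 3 `Cc1ccc(NC2=CC(=O)c3c(nc4n3[C@H]3OC[C@@H](O)[C@H]3OC4)C2=O)cc1C`: 1050 nM

In this assay compound 3 gives 1050 nM, but this value does not stand apart from the other two. Every step among the three compounds lies within the scatter, so the set shows no ranking.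

Compound 4 `O=C1C(N2CCC2)=CC(=O)c2c1nc1n2[C@H]2OC[C@@H](O)[C@H]2OC1` has azetidin-1-yl in place of (3,4-dimethylphenyl)amino on a double-bonded ring carbon. This change is far larger than any tested so far. The measured steps only alter groups on the aromatic ring: a 1.3-fold lower number from compound 1 to compound 2 (0.12 log units; within the scatter), a 1.5-fold lower number from compound 2 to compound 3 (0.17 log units; within the scatter) and a 1.9-fold lower number from compound 1 to compound 3 (0.28 log units; within the scatter). They show that these small edits leave the number within the scatter, but they say nothing about removing the whole aromatic ring and the amine hydrogen. Within the data shown here, no measured compound lacks that ring, so the direction is uncertain.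

A modest move toward weaker inhibition is the tentative expectation, and a result beyond the scatter in either direction would be no surprise. The expected change is a 2.4-fold higher number from compound 3 to compound 4 (0.38 log units; beyond the scatter). For compound 4 the estimated value is 2500 nM, with an expected range of 500 nM to 12000 nM.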

Compound 4, half-maximal inhibitory concentration: > 16000 nM
Compound 4 gave a limit, no number (the forecaster's own chance of this, stated with the estimate: 10%); middle value at least 6.4-fold (0.80 log units) from the limit.
By their numbers in this assay, from the lowest: compounds 3, 2 and 1 (each within the scatter of the next). At a limit, above all of these: compound 4.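

In this assay, compound 4 gives only a limit of the assay and not a number, and it is the only compound shown that does so: the limit of > 16000 nM in this assay, at which 1 of the 4 values shown sits. The earlier edits to groups on the aromatic ring all stayed within the scatter, but this position responds strongly once azetidin-1-yl replaces the whole substituted phenylamino group on the double-bonded ring carbon. The loss of inhibition is beyond the scatter against each of the three earlier compounds (an at least 15-fold higher number from compound 3 to compound 4 (1.18 log units; beyond the scatter)) (an at least 10-fold higher number from compound 2 to compound 4 (1.01 log units; beyond the scatter)) (an at least 7.9-fold higher number from compound 1 to compound 4 (0.89 log units; beyond the scatter)), so the good fit of small changes on the aromatic ring does not extend to a swap of this size.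

This single change removes both the aromatic ring and the amine hydrogen, so the compounds shown cannot tell which of the two losses matters. A cyclohexylamino group would keep the amine hydrogen without the aromatic ring, and a methyl(phenyl)amino group would keep the aromatic ring without that hydrogen, so either one would help separate the two.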